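This account rests on a few compounds, and the source may have more. Where it says the series, first, only, none or still open, it means among the compounds named here.

Measured so far in an ADME assay on Jurkat cells (Homo sapiens) for cytotoxicity, read by trypan blue exclusion, with a stated time of 24 h (a lower number here means a stronger inhibitor, a higher number a weaker inhibitor), for three compounds
Compound 1 `N#C[Se]Cc1ccc([N+](=O)[O-])cc1` gives 6860 nM
Compound 2 `N#C[Se]Cc1ccc(Br)cc1` gives 12700 nM
Compound 3 `CSc1ccc(C[Se]C#N)cc1` gives 5070 nM

Compound 1 holds the middle place among these three numbers, within the scatter of both others. Compound 4 `N#C[Se]CCc1ccc([N+](=O)[O-])cc1` keeps the core of compound 1 and carries this change: a group of 4 heavy atoms (2 carbon, 1 nitrogen, 1 selenium; no ring) in place of a group of 3 heavy atoms (1 carbon, 1 nitrogen, 1 selenium; no ring), on a saturated chain carbon bound to an aromatic carbon in the group on a saturated chain carbon bound to an aromatic carbon. Within the data shown here, no measured step touches that place, since all three swap a group on an aromatic carbon. Among the measured compounds shown here, they bear on it only indirectly, as a gauge of how far the numbers move in this small set: a 1.9-fold higher number from compound 1 to compound 2 (0.27 log units; within the scatter) and a 1.4-fold lower number from compound 1 to compound 3 (0.13 log units; within the scatter) and also a 2.5-fold lower number from compound 2 to compound 3 (0.40 log units; beyond the scatter) as the one modest step. The expectation in this assay is therefore no step beyond the scatter, in either direction, starting from compound 1 at 6860 nM as the anchor. The estimate for compound 4 is 7500 nM as an expected value, with an expected range of 3000 nM to 19000 nM around it. That estimate means a 1.1-fold higher number from compound 1 to compound 4 (0.04 log units; within the scatter) as the expected step.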

Compound 4, half-maximal inhibitory concentration: 2400 nM
Compound 4: middle estimate off by 3.1-fold (0.49 log units), on the high side, outside the stated range (below it).
By their numbers in this assay, from the lowest: compound 4; then compounds 3, 1 and 2 (each within the scatter of the next, the first and the last beyond it).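

In this assay, the change on a saturated chain carbon bound to an aromatic carbon gives a 2.9-fold lower number from compound 1 to compound 4 (0.46 log units; beyond the scatter) as the only step shown at that place. The group of 4 heavy atoms in place of the group of 3 heavy atoms therefore moves the number beyond the scatter, whereas the steps from compound 1 that put bromo or methylsulfanyl in place of nitro on an aromatic carbon stayed within it. Nothing among the data shown accounts for this step.

The compounds shown leave open whether a longer chain at this place would carry the number further in the same direction or reverse it. They also leave open whether the same change gives a step of similar size when bromo or methylsulfanyl stands in place of nitro.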